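The source may report more compounds than this note shows. Statements on the series, on what has been measured and on what is new or still open speak of the compounds shown alone.

Compound 1 `Cc1cccc(-n2nncc2CN2C(=O)C3(C(C#N)=C(N)Oc4c(N)cc5nc6ccccc6nc5c43)c3ccccc32)c1` in a functional assay on A549 cells (Homo sapiens) for antiproliferative activity, read by MTT assay, with a stated time of 48 h; a higher number here means a weaker inhibitor, a lower number a stronger inhibitor: 12300 nM
Compound 2 `N#CC1=C(N)Oc2c(N)cc3nc4ccccc4nc3c2C12C(=O)N(Cc1cnnn1-c1ccccc1Cl)c1ccccc12` in this assay: 29800 nM
Compound 3 `Cc1cc(C)cc(-n2nncc2CN2C(=O)C3(C(C#N)=C(N)Oc4c(N)cc5nc6ccccc6nc5c43)c3ccccc32)c1` in this assay: 31200 nM

Compound 3 has the highest of the three numbers in this assay. Its nearest neighbour is compound 2, whose value lies within the scatter of that of compound 3; compound 1 is furthest away, the gap being a 2.5-fold higher number from compound 1 to compound 3 (0.40 log units; beyond the scatter).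

Compound 4 `N#CC1=C(N)Oc2c(N)cc3nc4ccccc4nc3c2C12C(=O)N(Cc1cnnn1-c1ccc(Cl)cc1Cl)c1ccccc12` has not yet been measured. It differs from compound 3 in one place: 2,4-dichlorophenyl in place of 3,5-dimethylphenyl on an aromatic nitrogen.

Among the compounds with values here, two measured steps bear on this change. The first is a 2.4-fold higher number from compound 1 to compound 2 (0.38 log units; beyond the scatter), where a chlorinated phenyl replaced a methylated phenyl on the same aromatic nitrogen and gave a modest rise. The second is a 1.0-fold higher number from compound 2 to compound 3 (0.02 log units; within the scatter), where the chlorinated and the dimethylated phenyl groups gave the same number within the scatter. Within the data shown here, no measured step adds a second chlorine to this phenyl, so the effect of the extra chlorine of compound 4 is not covered by the data. Taken together, the account expects for compound 4 a step of about a 1.2-fold higher number from compound 3 to compound 4 (0.06 log units; within the scatter) in this assay, that is, no change clearly beyond the scatter, with a slight lean toward a higher number. The estimate for compound 4 in this assay is therefore 36000 nM, with a range from 15000 nM to 85000 nM.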

Compound 4, half-maximal inhibitory concentration: > 50000 nM
Compound 4 was reported as a limit; the forecaster's own chance of this, stated with the estimate: 10%; middle value at least 1.3-fold (0.14 log units) from the limit.
By their numbers in this assay, from the lowest: compound 1; then compounds 2 and 3 (each within the scatter of the next). At a limit, above all of these: compound 4.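

Compound 4 is reported in this assay only as a limit: the limit of > 50000 nM in this assay, at which 1 of the 4 values shown sits.

Within the data shown here, putting 2,4-dichlorophenyl in place of 3-methylphenyl on the aromatic nitrogen gives an at least 4.0-fold higher number from compound 1 to compound 4 (0.60 log units; beyond the scatter), and this floor is already larger than any step among the earlier compounds, so the position tolerates a change of aryl group less well than those steps alone suggested. The other two steps, an at least 1.6-fold higher number from compound 3 to compound 4 (0.20 log units; that floor lies within the scatter) and an at least 1.6-fold higher number from compound 2 to compound 4 (0.22 log units; that floor lies within the scatter), do not settle whether the second chloro or the exchange of 3,5-dimethylphenyl for 2,4-dichlorophenyl moves the number beyond the scatter, since each gives only a floor.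

Going by these compounds, all four compounds carry a phenyl ring with only methyl or chloro on it at this nitrogen, so the effect of a methoxy group, an amine or a carboxylic acid on that ring remains open, as does that of a plain phenyl or a longer alkyl chain in its place. With a single cell line shown, it also remains open whether this order of compounds 1 to 4 holds in any other cells.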